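Hydroxy to methoxy on the shared core

The source may hold more compounds than are shown below. What is called first, only, known or untested is meant among the compounds shown, and "the series" means these compounds.

In a functional assay on NCI-H1299 cells (Homo sapiens) for cytotoxicity, read by resazurin assay, with a stated time of 72 h (on this read-out lower numbers stand for stronger inhibition and higher numbers for weaker inhibition), compound 1 `COc1cc(/C=C/C(=O)OCCCCCCO[N+](=O)[O-])ccc1O` gives > 50000 nM as a limit of the assay, not a number. Compound 2 `O=C(/C=C/c1ccc(OCCCCCCO[N+](=O)[O-])c(O)c1)OCCCCCCO[N+](=O)[O-]` gives > 50000 nM as a limit as well. Compound 2 thus sits at the limit of > 50000 nM in this assay, at which 2 of the 2 values shown sit, and offers no number to step from. Compound 3 `COc1cc(/C=C/C(=O)OCCCCCCO[N+](=O)[O-])ccc1OCCCCCCO[N+](=O)[O-]` arises from compound 2 by methyl in place of hydrogen on an oxygen on an aromatic ring as the change of hydroxy to methoxy. For the measured compounds named here, no measured step covers this change. In this assay the expected a number no higher from compound 2 to compound 3 (the limit leaves the size open) lies within the scatter, in no set direction. Compound 3 is estimated at 50000 nM with an expected range of 25000 nM to 100000 nM in this read-out.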

Compound 3, half-maximal inhibitory concentration: > 50000 nM
Compound 3: a limit, no number; the forecaster's own chance of this, stated with the estimate: 85%; the middle value lies on the limit itself.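

No new step can be read from compound 3 to compound 1 or compound 2, because all three stand at one limit: the limit of > 50000 nM in this assay, at which 3 of the 3 values shown sit.

Left open are the actual values of these compounds, and so the size and direction of either change on the shared core.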